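Swapping the amide aryl group on an acetamido core

The compounds below may be only part of what the source reports. "The series", "measured", "known", "first", "only" and "open" are said of these compounds alone.

Of the compounds shown here, two sharing a core have been measured so far. Compound 1 `Nc1cccc2c(-c3cccc(NC(=O)c4ccc(Cl)c(C(F)(F)F)c4)c3)ccnc12` carries an amino group on the core and a 4-chloro-3-(trifluoromethyl)phenyl group on the amide; in a functional assay on M14 cells (Homo sapiens) for antiproliferative activity, read by sulforhodamine B assay, with a stated time of 48 h (a higher number here means a weaker inhibitor, a lower number a stronger inhibitor), compound 1 gives 3300 nM. Compound 2 `COc1ccc(C(=O)Nc2cccc(-c3ccnc4c(NC(C)=O)cccc34)c2)cc1OC` carries an acetamido group on the core and a 3,4-dimethoxyphenyl group on the amide; in this assay compound 2 gives 690 nM, the lowest of the two numbers, with the difference to compound 1 lying beyond the usual scatter.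

Compound 3 `CC(=O)Nc1cccc2c(-c3cccc(NC(=O)c4ccc(Cl)c(C(F)(F)F)c4)c3)ccnc12` keeps the acetamido group of compound 2 and changes the amide aryl group: 4-chloro-3-(trifluoromethyl)phenyl in place of 3,4-dimethoxyphenyl on a carbonyl carbon. Among the measured compounds shown here, no pair of measured compounds shows this exchange on its own, and compound 1, the only measured compound with the entering group, also differs in the group on the core. The step is therefore uncertain; a weakening is expected, but a modest one, because compound 1 with the same aryl group gives 3300 nM. For compound 3 the expected value is 1500 nM, with a range from 500 nM to 5000 nM, which would mean an expected step of a 2.2-fold higher number from compound 2 to compound 3 (0.34 log units; beyond the scatter).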

Compound 3, half-maximal inhibitory concentration: 3300 nM
Estimate against measurement, compound 3: 2.2-fold (0.34 log units) below; low and high end bracket the measured number.
By their numbers in this assay, from the lowest: compound 2; then compounds 1 and 3 (each within the scatter of the next).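

In this assay, with the acetamido group held in place, 4-chloro-3-(trifluoromethyl)phenyl in place of 3,4-dimethoxyphenyl on the carbonyl carbon gives a 4.8-fold higher number from compound 2 to compound 3 (0.68 log units; beyond the scatter), so the exchange of amide aryl groups can now be read on its own and favours 3,4-dimethoxyphenyl in this pair. With the 4-chloro-3-(trifluoromethyl)phenyl group held in place, acetyl in place of hydrogen on the nitrogen on the aromatic ring gives no change at the digits printed from compound 1 to compound 3 (within the scatter), so this change on the core leaves the number where it was. Among these compounds, then, only the change of the amide aryl group has moved the number beyond the scatter.

Nothing shown here explains why the aryl exchange moves the number. As far as these compounds go, it remains open whether acetyl in place of hydrogen is equally silent when 3,4-dimethoxyphenyl sits on the amide, and whether one methoxy group alone, an unsubstituted phenyl or a phenyl carrying a carboxylic acid would keep the lower number of compound 2 690 nM.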